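Amide variation on a shared imidazopyridine-type core: next step

This account rests on a few compounds, and the source may have more. Where it says the series, first, only, none or still open, it means among the compounds named here.

Compound 3 `O=C(c1ccc(-c2ccc3ncc(-c4cnc5ccccc5c4)n3c2)cc1)N1CCC(N2CCCCC2)CC1` gives 48.8% in an assay on Sf21 cells for inhibition of MAP kinase-interacting serine/threonine-protein kinase 2 (Homo sapiens), read by luminescence and ADP-Glo, with stated times of 10 min and 40 min, tested at 500 nM (a higher number here means more inhibition at the concentration tested (going by the name of the read-out), a lower number less inhibition), which places it second highest of the three numbers in hand. Compound 1 `O=C(c1ccc(-c2ccc3ncc(-c4ccc5ncccc5c4)n3c2)cc1)N1CCNCC1` gives 49.9% in this assay, within the scatter of compound 3. Within the data shown here, compound 2 `O=C(c1ccc(-c2ccc3ncc(-c4cnc5ccccc5c4)n3c2)cc1)N1CCOCC1` gives 21%, and the one measured step, a number 27.8 percentage points higher from compound 2 to compound 3 (beyond the scatter), is the only change in this assay that goes beyond the scatter.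

Compound 4 `O=C(c1ccc(-c2ccc3ncc(-c4cnc5ccccc5c4)n3c2)cc1)N1CCNCC1` is the next step, with the change (piperazin-1-yl in place of 4-(piperidin-1-yl)piperidin-1-yl on a carbonyl carbon). Among the measured compounds shown here, no measured step covers a piperazin-1-yl entering at the carbonyl carbon on this core; the closest point of reference is compound 1, which carries piperazin-1-yl on a differently joined core and gives 49.9%, within the scatter of compound 3. The measured step from compound 2 to compound 3 shows that the amide ring can move the read-out considerably, but it runs between two other groups. On these numbers, the expected step of a number 3.8 percentage points lower from compound 3 to compound 4 (within the scatter) is none beyond the scatter. Compound 4 is estimated at 45%, in the range 25% to 65%.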

Compound 4, a percentage reported as inhibition, at one concentration (the size of the read-out at that concentration, not a potency): 68.1%
Estimate against measurement, compound 4: 23.1 percentage points below, and the stated range ends below it.
By their numbers in this assay, from the lowest: compound 2; then compounds 3 and 1 (each within the scatter of the next); then compound 4.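

On the shared core, piperazin-1-yl on the carbonyl carbon reads above both other amide groups in this assay, with a number 19.3 percentage points higher from compound 3 to compound 4 (beyond the scatter) and a number 47.1 percentage points higher from compound 2 to compound 4 (beyond the scatter) for the two changes. The larger 4-(piperidin-1-yl)piperidin-1-yl is therefore not required for inhibition at this concentration, and the amide ring can move the read-out well past the level reached by compound 3. With piperazin-1-yl held, quinolin-3-yl in place of quinolin-6-yl on an aromatic carbon gives a number 18.2 percentage points higher from compound 1 to compound 4 (beyond the scatter) as well, so the quinoline attachment is a second place that moves the read-out.

Going by these compounds, whether an added methyl group on the piperazin-1-yl ring or an open-chain amine on the same carbonyl carbon keeps this level remains open. Nothing at hand accounts for the higher read-out with piperazin-1-yl.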